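Swapping 4-methylphenyl for 4-fluorophenyl in a growth inhibitor

A few compounds are considered here, and "the series" means these few. Any claim that something is new, unique, unknown or untested is made for them only; others in the source may bear on it.

In a functional assay on A549 cells (Homo sapiens) for antiproliferative activity, read by sulforhodamine B assay, with a stated time of 48 h (a lower number here means a stronger inhibitor of growth, a higher number a weaker inhibitor of growth), compound 1 (`Cc1cc2c(cc1C)C(Cl)=C(c1nnc(-c3ccccc3)o1)CCC2`) gives 1960 nM while compound 2 (`Cc1ccc(-c2nnc(C3=C(Cl)c4cc(C)c(C)cc4CCC3)o2)cc1`) gives 2470 nM as its result. These two numbers lie within the scatter of each other, so compound 2 stands level with compound 1 and not apart from it. Compound 3 (`Cc1cc2c(cc1C)C(Cl)=C(c1nnc(-c3ccc(F)cc3)o1)CCC2`) differs from compound 2 by a single swap (fluoro in place of methyl on an aromatic carbon): fluoro in place of methyl on an aromatic carbon, para to a large group. Going by the values given here, the only measured step touching this carbon is methyl in place of hydrogen (a 1.3-fold higher number from compound 1 to compound 2 (0.10 log units; within the scatter)), and it stayed within the scatter. Among the compounds with values here, with so small a step as the only guide, no change beyond the scatter is expected in this assay for the new swap. The expected step (a 1.1-fold lower number from compound 2 to compound 3 (0.05 log units; within the scatter)) is correspondingly small. Compound 3 is therefore estimated at 2200 nM (expected range 900 nM to 5500 nM).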

Compound 3, concentration for 50% growth inhibition: 2810 nM
Estimate against measurement, compound 3: 1.3-fold (0.11 log units) below, and the stated range covers the measured number.
By their numbers in this assay, from the lowest: compounds 1, 2 and 3 (each within the scatter of the next).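

At this aromatic carbon, para to a large group, this assay now allows hydrogen, methyl and fluoro to be compared, and none of the three stands apart: fluoro in place of methyl gives a 1.1-fold higher number from compound 2 to compound 3 (0.06 log units; within the scatter) and fluoro in place of hydrogen gives a 1.4-fold higher number from compound 1 to compound 3 (0.16 log units; within the scatter). The earlier finding for methyl therefore extends to fluoro, so two different single-atom-sized replacements for hydrogen have now left the result level at this carbon. Nothing available here offers a reason for this sameness.

From the compounds shown here alone, whether an amine, a carboxylic acid or a longer chain at this carbon would move the number beyond the scatter remains open. Also open, going by these compounds, is whether the same levelness would hold on a changed version of the shared core or in other cell lines.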